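Isobutyl to 4-Chlorophenoxy: an Expected Rise in Permeability

This account rests on a few compounds, and the source may have more. Where it says the series, first, only, none or still open, it means among the compounds named here.

Measured so far:
- compound 1 `COc1ccc(F)cc1CNCCCNc1ccnc2cc(C3CCCCC3)ccc12`: in an ADME assay for permeability, using PAMPA, with a stated time of 30 min, at pH 7.4 (a lower number here means that the compound crosses the layer more slowly, a higher number that the compound crosses the layer faster), compound 1 gives 23 10^-6 cm/s
- compound 2 `CC(C)Cc1ccc2c(NCCCNCc3ccco3)ccnc2c1`: in this assay compound 2 gives 23 10^-6 cm/s
- compound 3 `COc1cccc(Oc2ccc3c(NCCCNCc4cccc(OC)c4O)ccnc3c2)c1`: in this assay compound 3 gives 317 10^-6 cm/s

Compound 2 stands level with compound 1 at the digits shown, and the two together form the lowest pair of the three numbers; their gap is within the usual scatter, so no order between them can be read. Compound 3 lies far above compound 2, a gap that is well beyond the scatter.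

Compound 4 `Clc1ccc(Oc2ccc3c(NCCCNCc4ccco4)ccnc3c2)cc1` has not yet been measured in this assay. Against compound 2 it differs in one place: 4-chlorophenoxy in place of isobutyl on an aromatic carbon. Among the measured compounds shown here, no measured pair differs in exactly this way, so no direct step size is available from the data. For the measured compounds named here, the only measured compound that carries an aryl ether on the shared core is compound 3, and in this assay compound 3 gives 317 10^-6 cm/s. Because compound 3 gives 317 10^-6 cm/s, an upward step well beyond the scatter is expected from compound 2 to compound 4, estimated at a 6.5-fold higher number from compound 2 to compound 4 (0.81 log units; beyond the scatter). For compound 4 the expected value is 150 10^-6 cm/s, within an estimated range from 40 10^-6 cm/s to 400 10^-6 cm/s.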

Compound 4, apparent permeability: 317 10^-6 cm/s
Compound 4: middle estimate off by 2.1-fold (0.32 log units), on the low side; measured number inside the range.
By their numbers in this assay, from the lowest: compounds 1 and 2 (each within the scatter of the next); then compounds 3 and 4 (each within the scatter of the next).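

Among the compounds shown here, putting 4-chlorophenoxy in place of isobutyl on the aromatic carbon, with the rest of the molecule unchanged, gives a 14-fold higher number from compound 2 to compound 4 (1.14 log units; beyond the scatter) in this assay; this is the first direct evidence that a single change at this position can move the read-out well beyond the scatter. The entering group differs from isobutyl in several ways at once, with 8 heavy atoms instead of 4, one six-membered aromatic ring of carbon only and 1 hydrogen-bond acceptor, so this one step cannot show which of these differences matters. No supporting measurement is available to explain the size of the step.

The compounds shown leave open what a plain phenoxy group without the chlorine, a phenyl ring joined directly to the aromatic carbon, or a simple methoxy group would give at this position, and such groups could begin to separate the roles of the chlorine, the oxygen and the ring. They also leave open whether a charged group at this position, such as an amine or a carboxylic acid, would give a step of similar size or one in the opposite direction.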